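Methoxy in place of methyl: compound 3 from compound 2

This account rests on a few compounds, and the source may have more. Where it says the series, first, only, none or still open, it means among the compounds named here.

Series so far: compound 1 `Cc1nc(Nc2cc(C)c(C#N)cc2C)c(=O)n(C(C)C2CC2)n1` gives 60 nM in an assay on isolated protein for displacement of a labelled ligand from corticotropin-releasing factor receptor 1 (Rattus norvegicus) (a higher number here means a weaker inhibitor, a lower number a stronger inhibitor), and compound 2 `CCC(C1CC1)n1nc(C)nc(Nc2cc(C)c(C#N)cc2C)c1=O` gives 9.3 nM. Among the compounds with values here, the one step between them, a 6.5-fold lower number from compound 1 to compound 2 (0.81 log units; beyond the scatter), sits on the saturated chain. Compound 2 holds the lowest number of the two measured values, with compound 1 the nearest at the step just named.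

Compound 3 `CCC(C1CC1)n1nc(C)nc(Nc2cc(OC)c(C#N)cc2C)c1=O` differs from compound 2 by methoxy in place of methyl on an aromatic carbon. Within the data shown here, no measured step touches this aromatic carbon; the only step in hand concerns the chain and carries no information on a methoxy at this place. With nothing to lean on, the expected change is none beyond the scatter, and the range is set wide. Compound 3 is expected to give about 12 nM in this assay, between 3 nM and 50 nM. The step this implies, a 1.3-fold higher number from compound 2 to compound 3 (0.11 log units; within the scatter), is an expectation only.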

Compound 3, half-maximal inhibitory concentration: 13 nM
Beside the measured number, compound 3's estimate is 1.1-fold (0.03 log units) below it, within the range that was stated.
By their numbers in this assay, from the lowest: compounds 2 and 3 (each within the scatter of the next); then compound 1.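

In this assay, the step at this aromatic carbon, ortho to a cyano group and para to a methyl group, is a 1.4-fold higher number from compound 2 to compound 3 (0.15 log units; within the scatter), so methoxy in place of methyl cannot be told apart from compound 2 here. Within the data shown here, this is the first reading at this place, as the earlier step concerned only the saturated chain, and it shows that one extra heavy atom and one hydrogen-bond acceptor can enter here with no step beyond the scatter. No measured evidence bearing on the reason for this result is available.

Still open, as far as these compounds go, is whether a larger ethoxy group, a chlorine atom or a dimethylamino group at this aromatic carbon would stay level with compound 2 and compound 3. Also open, from the compounds shown here alone, is whether methoxy here would read the same with the chain of compound 1.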